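A few compounds are considered here, and "the series" means these few. Any claim that something is new, unique, unknown or untested is made for them only; others in the source may bear on it.

Measured so far in a functional assay on HepG2 cells (Homo sapiens) for cytotoxicity, read by MTT assay, with a stated time of 72 h; a higher number here means a weaker inhibitor, a lower number a stronger inhibitor:
- Compound 1 `COc1ccc2ccc(=O)oc2c1C1=NN(C(N)=O)C(c2ccc(SC)cc2)C1`: 18 nM
- Compound 2 `COc1ccc2ccc(=O)oc2c1C1=NNC(c2ccc(C)cc2)C1`: 43 nM
- Compound 3 `COc1ccc2ccc(=O)oc2c1C1=NN(c2ccccc2)C(c2ccc(C)cc2)C1`: 51 nM

In this assay compound 3 gives 51 nM, a number that cannot be told apart from that of compound 2. Only compound 1, at 18 nM, lies lower by more than the scatter. The next compound, compound 4 `COc1ccc2ccc(=O)oc2c1C1=NN(C(N)=O)C(c2ccc(C)cc2)C1`, keeps the 4-methylphenyl group of compound 3 and has carbamoyl in place of phenyl on an amine nitrogen in a ring.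

Within the data shown here, one measured step bears directly on this position: a 1.2-fold higher number from compound 2 to compound 3 (0.07 log units; within the scatter), which swaps phenyl for hydrogen on the same nitrogen and stays within the scatter. It shows that phenyl there brought no measurable change, but it says nothing about carbamoyl. Among the measured compounds shown here, the only evidence for carbamoyl is compound 1 at 18 nM, which carries that group on this nitrogen but lacks the 4-methylphenyl group, so it is an imperfect guide. For the measured compounds named here, no measured pair isolates the carbamoyl group alone.

On this evidence, a modest move towards compound 1 is expected rather than a large shift. The expected change is a 2.0-fold lower number from compound 3 to compound 4 (0.29 log units; within the scatter), towards a lower number. Compound 4 is estimated at 26 nM, with an expected range from 11 nM to 60 nM.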

Compound 4, half-maximal inhibitory concentration: 46 nM
Estimate against measurement, compound 4: 1.8-fold (0.25 log units) below; the measured number falls inside the stated range.
By their numbers in this assay, from the lowest: compound 1; then compounds 2, 4 and 3 (each within the scatter of the next).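

With the 4-methylphenyl group held fixed, hydrogen, phenyl and carbamoyl on the amine nitrogen in a ring cannot be told apart in this assay: the change from phenyl to carbamoyl gives a 1.1-fold lower number from compound 3 to compound 4 (0.04 log units; within the scatter), and the change from hydrogen to carbamoyl gives a 1.1-fold higher number from compound 2 to compound 4 (0.03 log units; within the scatter), so the two added groups, despite their different sizes and counts of hydrogen-bond donors and acceptors, leave the number within the scatter. Carbamoyl on this nitrogen therefore does not account for what sets compound 1 apart, as compound 4 carries the same group; the one difference left between them gives a 2.6-fold higher number from compound 1 to compound 4 (0.41 log units; beyond the scatter), methyl in place of methylsulfanyl on an aromatic carbon, and this is the only new step beyond the scatter. Nothing shown gives a reason for the flat response at the nitrogen or for the step at the aromatic carbon.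

Compound 1 is the only compound shown with methylsulfanyl, so it remains open whether hydrogen or phenyl on the nitrogen would match carbamoyl alongside that group. Also open, from the compounds shown here alone, is how an acetyl group or a longer chain on the nitrogen, or a methoxy group or chlorine in place of methyl or methylsulfanyl on the aromatic carbon, would read in this assay.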